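Hydroxy scan on the quinoline hydrazone series: cytotoxicity

The source may report more compounds than this note shows. Statements on the series, on what has been measured and on what is new or still open speak of the compounds shown alone.

Measured compounds:
- compound 1, `O=C(N/N=C/c1ccccc1O)c1ccc2ccccc2n1`: 56000 nM
- compound 2, `O=C(N/N=C/c1cccc(O)c1O)c1ccc2ccccc2n1`: 99600 nM
- compound 3, `O=C(N/N=C/c1ccc(O)cc1O)c1ccc2ccccc2n1`: 11700 nM

All three share the same core and differ only in the hydroxy pattern on the benzylidene ring. In an ADME assay on U-937 cells (Homo sapiens) for cytotoxicity, read by MTT assay, with a stated time of 72 h (a lower number here means that less compound is tolerated, a higher number that more compound is tolerated), compound 1 sits second highest of the three numbers; its nearest neighbour is compound 2, with a 1.8-fold higher number from compound 1 to compound 2 (0.25 log units; within the scatter), a step within the scatter, and its furthest is compound 3, with a 4.8-fold lower number from compound 1 to compound 3 (0.68 log units; beyond the scatter), a modest step beyond the scatter.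

Compound 4, `O=C(N/N=C/c1cc(O)ccc1O)c1ccc2ccccc2n1`, is not yet measured. It differs from compound 1 by hydroxy in place of hydrogen on an aromatic carbon. For the measured compounds named here, two measured steps bear on this change, both being a hydroxy in place of hydrogen on an aromatic carbon of the same ring: the step to compound 2 was flat, the step to compound 3 a modest drop. On that basis the expected step in this assay from compound 1 to compound 4 is a lowering, most likely modest, estimated as a 2.2-fold lower number from compound 1 to compound 4 (0.35 log units; beyond the scatter). The estimate for compound 4 is 25000 nM, expected to fall between 8000 nM and 80000 nM.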

Compound 4, concentration lethal to 50% of the cells: 159000 nM
Estimate against measurement, compound 4: 6.4-fold (0.80 log units) below; the measured number lies above the stated range.
By their numbers in this assay, from the lowest: compound 3; then compounds 1, 2 and 4 (each within the scatter of the next, the first and the last beyond it).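

In this assay, a hydroxy at this place, meta to a large group and para to a hydroxy group, gives a 2.8-fold higher number from compound 1 to compound 4 (0.45 log units; beyond the scatter). The same change on the same ring can therefore raise the number beyond the scatter as well as lower it, as in a 4.8-fold lower number from compound 1 to compound 3 (0.68 log units; beyond the scatter), while a 1.8-fold higher number from compound 1 to compound 2 (0.25 log units; within the scatter) remains within the scatter, so among these three steps the outcome depends on where the hydroxy enters. Nothing available explains why these places differ.

Still open, from the compounds shown here alone, is whether another group at this place, such as a methoxy group, an amine or a carboxylic acid, would move the number in the same direction as hydroxy. Also open, going by these compounds, is whether the rise seen with compound 4 would persist if the shared core were changed.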